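A few compounds are considered here, and "the series" means these few. Any claim that something is new, unique, unknown or untested is made for them only; others in the source may bear on it.

In a functional assay on A549 cells (Homo sapiens) for antiproliferative activity, read by MTT assay, with a stated time of 48 h (a higher number here means a weaker inhibitor, a lower number a stronger inhibitor), compound 1 (`CCOc1cc(-c2ccc3[nH]ccc3c2)cn2c(-c3cc(OC)c(OC)c(OC)c3)nnc12`) gives 589 nM and compound 2 (`COc1cc(-c2nnc3c(OC4CC4)cc(-c4ccc5[nH]ccc5c4)cn23)cc(OC)c1OC`) gives 198 nM. Swapping the group on the oxygen accounts for a 3.0-fold lower number from compound 1 to compound 2 (0.47 log units; beyond the scatter). Compound 3 (`COc1cc(-c2nnc3c(OC)cc(-c4ccc5[nH]cc(C=O)c5c4)cn23)cc(OC)c1OC`) reads > 10000 nM in this assay, and this is a limit of the assay, not a number.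

Compound 4 (`COc1cc(-c2nnc3c(OC)cc(-c4ccc5c(ccn5C)c4)cn23)cc(OC)c1OC`) is next to be read. Its change is 1-methyl-1H-indol-5-yl in place of 3-formyl-1H-indol-5-yl on an aromatic carbon: 1-methyl-1H-indol-5-yl replaces 3-formyl-1H-indol-5-yl, and the methoxy group stays. For the measured compounds named here, the one measured step lies elsewhere on the molecule, so it sets only a rough scale and does not measure this change. The direction rests on compound 1 at 589 nM and compound 2 at 198 nM, neither of which carries the 3-formyl group. Neither compound carries the 1-methyl group either, so the range stays wide. A large move towards a lower number is expected in this assay, well beyond the scatter. The estimate amounts to an expected at least 33-fold lower number from compound 3 to compound 4 (1.52 log units; beyond the scatter). For compound 4 the estimated value is 300 nM, with an expected range of 50 nM to 2000 nM.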

Compound 4, half-maximal inhibitory concentration: 69 nM
Beside the measured number, compound 4's estimate is 4.3-fold (0.64 log units) above it; the range from low to high includes it.
By their numbers in this assay, from the lowest: compound 4; then compound 2; then compound 1. At a limit, above all of these: compound 3.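

At the aromatic carbon two atoms from the ring nitrogen, with the methoxy group held constant, 1-methyl-1H-indol-5-yl in place of 3-formyl-1H-indol-5-yl gives an at least 140-fold lower number from compound 3 to compound 4 (2.16 log units; beyond the scatter) in this assay. For the compounds shown here, the earlier measured step covered only the group on the oxygen, so this is the first reading of how strongly the result in this assay depends on the group at this aromatic carbon. Compound 3 stands at a limit of the assay, not a number, so the step gives only a lower bound on the size of the change: the limit of > 10000 nM in this assay, at which 1 of the 4 values shown sits.

The swap removes the 3-formyl group and the indole hydrogen-bond donor and adds the 1-methyl group in a single step, so the contribution of each remains unresolved. Also open, on these data alone, is how a longer chain in place of the 1-methyl group, or an amine or a carboxylic acid in place of the 3-formyl group, would read.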